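Series notes: cytotoxicity on a shared core, hydroxy walk

The compounds below may be only part of what the source reports. "The series", "measured", "known", "first", "only" and "open" are said of these compounds alone.

Compound 3 `COc1ccccc1-c1nnc(-c2ccc(C(=O)N/N=C/c3ccccc3O)cc2)o1` shows the highest number of the three measured in an ADME assay on THP-1 cells (Homo sapiens) for cytotoxicity (on this read-out lower numbers stand for stronger inhibition and higher numbers for weaker inhibition), where compound 3 gives 207000 nM. For the measured compounds named here, compound 1 `COc1ccccc1-c1nnc(-c2ccc(C(=O)N/N=C/c3cccc([N+](=O)[O-])c3)cc2)o1` gives 119000 nM, and compound 2 `COc1ccccc1-c1nnc(-c2ccc(C(=O)N/N=C/c3ccc(O)c(O)c3)cc2)o1` gives 100000 nM; the shift a 1.7-fold higher number from compound 1 to compound 3 (0.24 log units; within the scatter) and the shift a 1.2-fold lower number from compound 1 to compound 2 (0.08 log units; within the scatter) are both small, while a 2.1-fold higher number from compound 2 to compound 3 (0.32 log units; beyond the scatter) is the one step beyond the scatter. Compound 4 `COc1ccccc1-c1nnc(-c2ccc(C(=O)N/N=C/c3cccc(O)c3O)cc2)o1` differs from compound 3 by hydroxy in place of hydrogen on an aromatic carbon. Going by the values given here, only the step from compound 2 to compound 3 touches on a change in hydroxy count on this ring, and it is modest, so at most a small move toward lower numbers is expected in this assay, estimated as a 1.4-fold lower number from compound 3 to compound 4 (0.14 log units; within the scatter). For compound 4 the expected value is 150000 nM, within 70000 nM to 350000 nM.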

Compound 4, half-maximal inhibitory concentration: 102000 nM
Compound 4: the middle estimate sits 1.5-fold (0.17 log units) above what was measured, within the range that was stated.
By their numbers in this assay, from the lowest: compounds 2, 4, 1 and 3 (each within the scatter of the next, the first and the last beyond it).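

In this assay, hydroxy in place of hydrogen on this aromatic carbon, ortho to a hydroxy group, gives a 2.0-fold lower number from compound 3 to compound 4 (0.31 log units; beyond the scatter) as a modest step. The 2,3-dihydroxyphenyl group reads no differently from the 3,4-dihydroxyphenyl group in a 1.0-fold higher number from compound 2 to compound 4 (0.01 log units; within the scatter) and no differently from the 3-nitrophenyl group in a 1.2-fold lower number from compound 1 to compound 4 (0.07 log units; within the scatter), so this added hydroxy brings no separation from those two groups. No supporting data explain the step. Open, from the compounds shown here alone, is whether an amine or a carboxylic acid on this same aromatic carbon would match hydroxy.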